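This account rests on a few compounds, and the source may have more. Where it says the series, first, only, none or still open, it means among the compounds named here.

Among the compounds with values here, compound 1, with structure `CCCCCC(=O)Nc1cccc(S(=O)(=O)Oc2ccccc2C(C)C)c1`, is the first of the set: in a functional assay on M21 cells (Homo sapiens) for antiproliferative activity, read by sulforhodamine B assay, with a stated time of 48 h (on this read-out lower numbers stand for stronger inhibition and higher numbers for weaker inhibition), compound 1 gives 11000 nM. Compound 2, with structure `CC(C)C(=O)Nc1cccc(S(=O)(=O)Oc2ccccc2C(C)C)c1`, differs from it by isopropyl in place of pentyl on a carbonyl carbon, and in this assay compound 2 gives 17000 nM, which means a 1.5-fold higher number from compound 1 to compound 2 (0.19 log units; within the scatter).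

Compound 3, with structure `CCCCCC(=O)Nc1ccc(S(=O)(=O)Oc2ccccc2C(C)C)cc1`, carries a different core; the difference between the two cores is not broken down here. In this assay compound 3 gives 6700 nM. Against compound 1 the two numbers sit within the usual scatter of each other, while against compound 2 the number of compound 3 is the lower of the two, by more than the scatter.

Compound 4, with structure `CC(C)C(=O)Nc1ccc(S(=O)(=O)Oc2ccccc2C(C)C)cc1`, has not been measured. It differs from compound 3 by isopropyl in place of pentyl on a carbonyl carbon, at the same place as before, so it is the same change already seen from compound 1 to compound 2. Within the data shown here, because that earlier step was a 1.5-fold higher number from compound 1 to compound 2 (0.19 log units; within the scatter), the expected step here is a 1.5-fold higher number from compound 3 to compound 4 (0.17 log units; within the scatter), with the one prior pair as its only support. On that basis compound 4 is estimated at 10000 nM in this assay, with a plausible range from 5000 nM to 20000 nM.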

Compound 4, half-maximal inhibitory concentration: 11000 nM
Compound 4: middle estimate off by 1.1-fold (0.04 log units), on the low side, and the stated range covers the measured number.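

In this assay, putting isopropyl in place of pentyl on the carbonyl carbon gives a 1.6-fold higher number from compound 3 to compound 4 (0.22 log units; within the scatter), and this step matches the earlier one on the other core: the same change on two cores in this assay, a 1.5-fold higher number (0.19 log units; within the scatter) from compound 1 to compound 2 and a 1.6-fold higher number (0.22 log units; within the scatter) from compound 3 to compound 4, 1.1-fold (0.03 log units) apart, within the scatter of two such steps. As far as these two pairs can show, the change carries from one core to the other with no visible dependence on the core. Each step on its own lies within the scatter, however, so the pairs do not establish that the change has any real effect on the read-out, and two cores say nothing about how it would behave on a third.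

The compounds shown carry only pentyl and isopropyl on the carbonyl carbon, which leaves open how a longer chain, a cyclohexyl group or a chain ending in an amine or a carboxylic acid would read in this assay. Going by these compounds, it also remains open whether the step would hold with a sulfonamide in place of the sulfonate ester.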